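The source may hold more compounds than are shown below. What is called first, only, known or untested is meant among the compounds shown, and "the series" means these compounds.

Measured so far:
- compound 1 `CC(NC(=O)COc1cc(C(F)(F)F)c2c(-c3ccccc3)nn(C)c2n1)c1ccccn1`: "not active" (no number reported) (no number reported)
- compound 2 `COc1ccc(CNC(=O)COc2cc(C(F)(F)F)c3c(-c4ccccc4)nn(C)c3n2)cc1`: 83 nM
- compound 3 `Cc1ccc([C@H](C)NC(=O)COc2cc(C)c3c(-c4ncccn4)nn(C)c3n2)cc1`: 5 nM

In a functional assay on isolated protein for antagonist activity at Orexin receptor type 2 (Homo sapiens), read by fluorescence, FLIPR and calcium flux, with a stated time of 1 h (on this read-out higher numbers stand for weaker inhibition and lower numbers for stronger inhibition), compound 3 gives the lowest of the two numbers available; compound 2, the nearest, sits well beyond the scatter above it, and compound 1 is reported without a number. Compound 2 and compound 3 differ at several places at once, so no single structural step can be read from them.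

Compound 4 `Cc1ccc([C@H](C)NC(=O)COc2cc(C)c3c(-c4cnccn4)nn(C)c3n2)cc1` differs from compound 3 in one place only: pyrazin-2-yl in place of pyrimidin-2-yl on an aromatic carbon. The two have the same atoms joined differently, and the change keeps the six-membered aromatic ring with two hetero atoms and two hydrogen-bond acceptors. Within the data shown here, no measured pair in the set isolates this change, so the expectation rests on compound 3 alone. The step of a 1.8-fold higher number from compound 3 to compound 4 (0.26 log units; within the scatter) in this assay is expected to be small, at most a modest loss, and plausibly within the scatter. Compound 4 is estimated at 9 nM, with a range from 2.5 nM to 30 nM.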

Compound 4, inhibition constant in the Orexin receptor type 2 assay: 15 nM
The estimate for compound 4 lay 1.7-fold (0.22 log units) below the measured number; low and high end bracket the measured number.
By their numbers in the Orexin receptor type 2 assay, from the lowest: compound 3; then compound 4; then compound 2.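

At this aromatic carbon of the five-membered aromatic ring, the series now has its first comparison that differs in one place. In the Orexin receptor type 2 assay, pyrazin-2-yl in place of pyrimidin-2-yl gives a 3.0-fold higher number from compound 3 to compound 4 (0.48 log units; beyond the scatter), so this position responds to how the same atoms are joined, even with the heavy-atom and hydrogen-bond acceptor counts unchanged. In a physicochemical assay for lipophilicity, measured as octanol-water partition (a higher number here means a more lipophilic compound, a lower number a more polar compound), compound 3 gives 3.3 and compound 4 gives 3.9. In this one pair, the weaker inhibition comes with higher lipophilicity in the physicochemical assay: the measured partition coefficient of compound 3, 3.3, and of compound 4, 3.9, a number 0.60 log units higher (beyond the scatter)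

A single pair cannot tell whether the higher lipophilicity and the weaker inhibition are linked or merely occur together. Also open, from the compounds shown here alone, is how a group of a different kind on this aromatic carbon, such as an amine or a carboxylic acid, would compare with pyrimidin-2-yl and pyrazin-2-yl.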